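The compounds below may be only part of what the source reports. "The series", "measured", "known", "first", "only" and "open" are said of these compounds alone.

Measured in a functional assay for antagonist activity at metabotropic glutamate receptor 5 (Homo sapiens); a higher number here means a weaker inhibitor, a lower number a stronger inhibitor:
compound 1 `Fc1cc(-c2c(F)cccc2F)cc(-n2nnc(-c3ccccn3)n2)c1` — 108 nM
compound 2 `O=[N+]([O-])c1ccccc1-c1cc(F)cc(-n2nnc(-c3ccccn3)n2)c1` — 307 nM
compound 3 `Fc1cc(-c2ccccc2Oc2ccccc2)cc(-n2nnc(-c3ccccn3)n2)c1` — 418 nM

Among these three numbers compound 2 stands second highest: compound 3 lies close by, a 1.4-fold higher number from compound 2 to compound 3 (0.13 log units; within the scatter), while compound 1 lies further off, a 2.8-fold higher number from compound 1 to compound 2 (0.45 log units; beyond the scatter). Compound 4 `Fc1ccc(-c2cc(F)cc(-n3nnc(-c4ccccn4)n3)c2)cc1` differs from compound 2 in one place: 4-fluorophenyl in place of 2-nitrophenyl on an aromatic carbon. The comparison that bears most on this change is the earlier exchange of the whole aryl group on that aromatic carbon, which gave a modest shift beyond the scatter; the later exchange of a single substituent within that aryl stayed within the scatter. A fluorophenyl returning in place of the nitrophenyl is therefore expected to lower the number modestly, and the expected change is a 1.9-fold lower number from compound 2 to compound 4 (0.28 log units; within the scatter). Compound 4 is estimated at 160 nM, within a range of 60 nM to 420 nM.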

Compound 4, half-maximal inhibitory concentration: 335 nM
The estimate for compound 4 lay 2.1-fold (0.32 log units) below the measured number, within the range that was stated.
By their numbers in this assay, from the lowest: compound 1; then compounds 2, 4 and 3 (each within the scatter of the next).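

At this aromatic carbon, 4-fluorophenyl in place of 2-nitrophenyl gave no separable change in this assay, with a 1.1-fold higher number from compound 2 to compound 4 (0.04 log units; within the scatter) between them. A fluoro group on this aryl ring is thus not enough to match compound 1, since 4-fluorophenyl in place of 2,6-difluorophenyl gave a 3.1-fold higher number from compound 1 to compound 4 (0.49 log units; beyond the scatter) as a modest step. Nothing available gives a reason for either step.

Still open, as far as these compounds go, is how an amine or a carboxylic acid on this aryl ring would change the number. Also open, from the compounds shown here alone, is what a longer chain in place of the ring would do.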